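The source may hold more compounds than are shown below. What is called first, only, known or untested is meant among the compounds shown, and "the series" means these compounds.

Two amides built on a shared core have been tested in an ADME assay on A2780 cells (Homo sapiens) for cytotoxicity, read by MTT assay, with a stated time of 72 h; a higher number here means a weaker inhibitor of growth, a lower number a stronger inhibitor of growth. Compound 1 (`CCCCCCCCCCNC(=O)C1C(C(=O)O)[C@@H]2CC[C@H]1O2`) gives 10000 nM, and compound 2 (`C=CCNC(=O)C1C(C(=O)O)[C@@H]2CC[C@H]1O2`), which carries an allyl group, gives 10000 nM, so compound 2 stands level with compound 1 within the usual scatter. Compound 3 (`CCCCNC(=O)C1C(C(=O)O)[C@@H]2CC[C@H]1O2`) has not been measured yet. It replaces the allyl group of compound 2 with butyl: propyl in place of vinyl on a saturated chain carbon bound to an amide-type nitrogen. Put simply, propyl takes the place of vinyl on a saturated chain carbon bound to an amide-type nitrogen. Among the measured compounds shown here, no measured pair yet shows what this exact change does. Compound 1 gives 10000 nM and compound 2 gives 10000 nM, the same reading, so no shift beyond the scatter is expected. The expected change is no change at the digits printed from compound 2 to compound 3 (within the scatter). For compound 3 the estimated value is 10000 nM, with an expected range from 5000 nM to 20000 nM.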

Compound 3, concentration for 50% growth inhibition: 10000 nM
Estimate against measurement, compound 3: no gap at the digits printed; the range from low to high includes it.
By their numbers in this assay, from the lowest: compounds 1, 2 and 3 (each within the scatter of the next).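

In this assay, propyl in place of vinyl on a saturated chain carbon bound to an amide-type nitrogen gives no change at the digits printed from compound 2 to compound 3 (within the scatter), so the saturated butyl chain reads the same as the allyl chain with its double bond. Hydrogen in place of hexyl on a saturated chain carbon, four bonds along the chain from an amide-type nitrogen, gives no change at the digits printed from compound 1 to compound 3 (within the scatter), so across these three amides neither the double bond nor the length of the chain moves the number. No measurement is available that would explain this agreement.

From the compounds shown here alone, whether an amine, a hydroxyl or a phenyl ring at the end of the chain would shift the reading remains open. So does the effect of an ester in place of the carboxylic acid on the shared core.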